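Swapping methylamino for methyl on a limited compound

The source may hold more compounds than are shown below. What is called first, only, known or untested is meant among the compounds shown, and "the series" means these compounds.

In a functional assay on HL-60 cells (Homo sapiens) for antiproliferative activity, read by XTT assay, with a stated time of 72 h (a higher number here means a weaker inhibitor, a lower number a stronger inhibitor), compound 3 `CNc1ncnc2c1c(I)cn2[C@@H]1O[C@H](CO)[C@@H](O)[C@H]1O` gives only a limit, > 20000 nM. Its closest measured neighbour, compound 1 `COc1ncnc2c1c(I)cn2[C@@H]1O[C@H](CO)[C@@H](O)[C@H]1O`, gives 2300 nM in this assay. Compound 2 `Cc1ncnc2c1c(-c1cc3ccccc3o1)cn2[C@@H]1O[C@H](CO)[C@@H](O)[C@H]1O` likewise reaches only a limit, > 20000 nM. The change from compound 3 to compound 4 `Cc1ncnc2c1c(I)cn2[C@@H]1O[C@H](CO)[C@@H](O)[C@H]1O` is methyl in place of methylamino on an aromatic carbon. Within the data shown here, the one measured step that touches the same place, an at least 8.6-fold higher number from compound 1 to compound 3 (0.93 log units; beyond the scatter), ran toward a weaker inhibitor and ended at the limit of > 20000 nM in this assay, at which 2 of the 3 values shown sit, so its full size is unknown. Among the measured compounds shown here, a methyl at this place has no measured step of its own here. The expected step is therefore an at least 6.6-fold lower number from compound 3 to compound 4 (0.82 log units; beyond the scatter), toward a stronger inhibitor but with little certainty. Compound 4 is estimated at 3000 nM, within 500 nM to 20000 nM.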

Compound 4, half-maximal inhibitory concentration: 2650 nM
For compound 4 the middle estimate is 1.1-fold (0.05 log units) above the measured one; the range from low to high includes it.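

In this assay, methyl at this place gives an at least 7.5-fold lower number from compound 3 to compound 4 (0.87 log units; beyond the scatter), so the loss seen with methylamino is not shared by every small group here. Methyl and methoxy cannot be told apart, with a 1.2-fold higher number from compound 1 to compound 4 (0.06 log units; within the scatter), which leaves methylamino as the one group of these three that goes against them. A second change, iodo in place of 1-benzofuran-2-yl, gives an at least 7.5-fold lower number from compound 2 to compound 4 (0.87 log units; beyond the scatter).

The full size of the two large steps stays unknown because compound 2 and compound 3 each give only a limit: the limit of > 20000 nM in this assay, at which 2 of the 4 values shown sit.
From the compounds shown here alone, whether a plain amine or an ethyl chain at this place would behave like methyl or like methylamino remains open.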